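Swapping the group on a sulfonamide nitrogen

The compounds below may be only part of what the source reports. "The series", "measured", "known", "first", "only" and "open" are said of these compounds alone.

Of the compounds shown here, two have been measured so far. In a functional assay on A2780 cells (Homo sapiens) for antiproliferative activity, read by MTT assay, with a stated time of 72 h (a higher number here means a weaker inhibitor of growth, a lower number a stronger inhibitor of growth), compound 1 (`COc1cc(OC)c(/C=C/S(=O)(=O)Cc2cnc(OC)c(OC)c2)c(OC)c1`) gives 930 nM as its result. In this assay compound 2 (`COc1cc(OC)c(/C=C/S(=O)(=O)Nc2ccc(Cl)nc2)c(OC)c1`) gives 2600 nM and so holds the higher of the two numbers, making it the weaker inhibitor of growth of the pair by a gap beyond the usual scatter.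

Compound 3 (`COc1cc(OC)c(/C=C/S(=O)(=O)Nc2cnc(Cl)cn2)c(OC)c1`) has not yet been measured. The change from compound 2 is 5-chloropyrazin-2-yl in place of 6-chloropyridin-3-yl on a sulfonamide nitrogen and it places 5-chloropyrazin-2-yl in place of 6-chloropyridin-3-yl on a sulfonamide nitrogen, leaving the shared core untouched.

Among the compounds with values here, no measured pair here shows what such an exchange does, so the data offer no step to borrow. The expectation in this assay is for no step beyond the scatter, in either direction, with compound 2 at 2600 nM as the only close anchor. The expected change is a 1.2-fold higher number from compound 2 to compound 3 (0.06 log units; within the scatter) and it stays small. For compound 3 the estimated value is 3000 nM with an expected range from 900 nM to 10000 nM in this estimate.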

Compound 3, concentration for 50% growth inhibition: > 10000 nM
Compound 3: a limit, no number (the forecaster's own chance of this, stated with the estimate: 5%); at least 3.3-fold (0.52 log units) between middle value and limit.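

In this assay compound 3 gives > 10000 nM, which is a limit of the assay and not a number. Placing 5-chloropyrazin-2-yl in place of 6-chloropyridin-3-yl on a sulfonamide nitrogen gives an at least 3.8-fold higher number from compound 2 to compound 3 (0.58 log units; beyond the scatter), the first step in this series that can be read, and it shows that this position does not tolerate every chlorinated six-membered aromatic ring equally, even though the two groups have the same count of heavy atoms and the entering ring differs by carrying 2 hetero atoms rather than 1. The size of this step remains open-ended, as it rests on a limit: the limit of > 10000 nM in this assay, at which 1 of the 3 values shown sits.

The compounds shown leave open whether the second ring nitrogen alone accounts for the step or whether the way the ring is attached also plays a part, since the two groups differ in both. They also leave open whether an amine or a nitrile in place of the chlorine on either ring would shift the result in this assay.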